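The source may hold more compounds than are shown below. What is called first, only, known or untested is meant among the compounds shown, and "the series" means these compounds.

Measured in a functional assay for inhibition, with Homo sapiens as the target; a higher number here means a weaker inhibitor, a lower number a stronger inhibitor:
- Compound 1 `COC(=O)CCCCCCCCn1nc(-c2ccccc2)c(-c2ccccc2)c1-c1ccccc1`: 4300 nM
- Compound 2 `O=C(O)CCCCCn1nc(-c2ccccc2)c(-c2ccccc2)c1-c1ccccc1`: > 78000 nM (a limit)

Compound 2 is known only through its limit of > 78000 nM, which is not a number, and it stands as the limit of > 78000 nM in this assay, at which 1 of the 2 values shown sits. Compound 3 `O=C(O)CCCCCCn1nc(-c2ccccc2)c(-c2ccccc2)c1-c1ccccc1` differs from compound 2 as follows: carboxymethyl in place of carboxy on a saturated chain carbon, five bonds along the chain from an aromatic nitrogen. In words, carboxymethyl stands in place of carboxy on a saturated chain carbon, five bonds along the chain from an aromatic nitrogen.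

Among the compounds with values here, only one measured step bears on this change, an at least 18-fold higher number from compound 1 to compound 2 (1.25 log units; beyond the scatter), which is large and beyond the scatter. It replaces 3-(methoxycarbonyl)propyl with carboxy, so it only partly resembles the present change, which reverses a small part of it and keeps the carboxy end. A modest move towards a lower number is therefore expected in this assay. The expected size is an at least 1.9-fold lower number from compound 2 to compound 3 (0.29 log units; that floor lies within the scatter). For compound 3 the estimated value is 40000 nM, with an expected range of 10000 nM to 150000 nM.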

Compound 3, half-maximal inhibitory concentration: 22400 nM
Compound 3: the middle estimate sits 1.8-fold (0.25 log units) above what was measured, and the stated range covers the measured number.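

The change from carboxy to carboxymethyl, on a saturated chain carbon, five bonds along the chain from an aromatic nitrogen, gives an at least 3.4-fold lower number from compound 2 to compound 3 (0.54 log units; beyond the scatter) in this assay, so a single added carbon already moves the value at this place. From the compounds shown here alone, the true size of this step remains open, as compound 2 is known only through a limit, which is not a number: the limit of > 78000 nM in this assay, at which 1 of the 3 values shown sits. Carboxy in place of 2-(methoxycarbonyl)ethyl, on a saturated chain carbon, six bonds along the chain from an aromatic nitrogen, gives a 5.2-fold higher number from compound 1 to compound 3 (0.72 log units; beyond the scatter), so the added carbon does not bring the acid series level with compound 1.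

The compounds shown leave open whether a longer chain ending in 3-carboxypropyl or 4-carboxybutyl would lower the number further. They also do not show how an amide or an amine at the chain end would compare with the methyl ester of compound 1.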